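The compounds below may be only part of what the source reports. "The series", "measured", "known", "first", "only" and "open" are said of these compounds alone.

Measured in a functional assay on NCI-H460 cells (Homo sapiens) for antiproliferative activity, read by sulforhodamine B assay, with a stated time of 72 h; on this read-out lower numbers stand for stronger inhibition and higher numbers for weaker inhibition:
compound 1 `CN(CCNCc1cn(-c2ccccc2Cl)nn1)CCNc1ccnc2cc(Cl)ccc12` gives 20000 nM;
compound 2 `CN(CCNCc1cn(Cc2nc3ccccc3[nH]2)nn1)CCNc1ccnc2cc(Cl)ccc12` gives 120000 nM.

For the measured compounds named here, of these two numbers, compound 2 stands at the higher one; the only step toward it, a 6.0-fold higher number from compound 1 to compound 2 (0.78 log units; beyond the scatter), shows that exchanging the group on the aromatic nitrogen of the triazole shifts the read-out modestly and beyond the scatter. Compound 3 `CN(CCNCc1cn(CCCn2nn[nH]c2=O)nn1)CCNc1ccnc2cc(Cl)ccc12` differs from compound 2 at the same place: a group of 8 heavy atoms (3 carbon, 4 nitrogen, 1 oxygen; one five-membered aromatic ring with 4 hetero atoms) in place of a group of 9 heavy atoms (7 carbon, 2 nitrogen; one five-membered aromatic ring with 2 hetero atoms, one six-membered aromatic ring of carbon only), on a saturated chain carbon bound to an aromatic nitrogen. Going by the values given here, no measured step involves the entering group, so the one step that bears on the change is a 6.0-fold higher number from compound 1 to compound 2 (0.78 log units; beyond the scatter), and it speaks only to the size such a swap can have, not to its direction for this new group. A change of modest size in either direction in this assay is therefore plausible, and the estimate stays close to compound 2. Compound 3 is expected to give about 100000 nM, in the range 30000 nM to 300000 nM, which means an expected step of a 1.2-fold lower number from compound 2 to compound 3 (0.08 log units; within the scatter).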

Compound 3, half-maximal inhibitory concentration: > 200000 nM
Compound 3 was reported as a limit; the forecaster's own chance of this, stated with the estimate: 20%; at least 2.0-fold (0.30 log units) between middle value and limit.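

For the compounds shown here, for compound 3 the result is a limit and not a number, and it is the only such reading here: the limit of > 200000 nM in this assay, at which 1 of the 3 values shown sits. The step of an at least 1.6-fold higher number from compound 2 to compound 3 (0.22 log units; that floor lies within the scatter) therefore does not separate the entering group from 1H-benzimidazol-2-yl, whereas an at least 10-fold higher number from compound 1 to compound 3 (1.00 log units; beyond the scatter) sets it clearly apart from 2-chlorophenyl on an aromatic nitrogen. Compound 3 thus adds a second case in which a group held on a saturated chain carbon gives a higher number than the 2-chlorophenyl group of compound 1, and no compound shown goes against this.

On these data alone, how far compound 3 truly lies from compound 2 remains open. Also open, as far as these compounds go, is whether a plain phenyl group, or a carboxylic acid or an amine at the end of a chain, would keep the number near that of compound 1.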